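Cytotoxicity notes: lengthening the hydroxyalkyl chain of compound 3

The source may hold more compounds than are shown below. What is called first, only, known or untested is meant among the compounds shown, and "the series" means these compounds.

Compound 3 `CS(=O)(=O)c1nn(Cc2nc3cc(Cl)ccc3n2CCO)c2cnccc12` carries a hydroxy on a saturated chain carbon, two bonds along the chain from an aromatic nitrogen. In an ADME assay on HEp-2 cells (Homo sapiens) for cytotoxicity, with a stated time of 4 days (a higher number here means that more compound is tolerated, a lower number that less compound is tolerated), compound 3 gives > 100000 nM, which is a limit of the assay and not a number. Compound 1 `CCS(=O)(=O)c1cn(Cc2nc3cc(Cl)ccc3n2CCCS(C)(=O)=O)c2ccccc12` gives > 100000 nM in this assay, again a limit. Compound 2 `CS(=O)(=O)CCCn1c(Cn2cc(S(=O)(=O)C3CC3)c3ccccc32)nc2cc(Cl)ccc21` gives > 100000 nM in this assay, likewise a limit. The step that the two limits leave unreadable from compound 1 to compound 2 therefore cannot be sized. What the numbers shown amount to is the limit of > 100000 nM in this assay, at which 3 of the 3 values shown sit.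

Compound 4 `CC(C)(O)CCCn1c(Cn2nc(S(C)(=O)=O)c3ccncc32)nc2cc(Cl)ccc21` differs from compound 3 by 2-hydroxy-2-methylpropyl in place of hydroxy on a saturated chain carbon, two bonds along the chain from an aromatic nitrogen. Within the data shown here, no measured step covers this change; the only bearing on it is the limit of > 100000 nM in this assay, at which 3 of the 3 values shown sit, with every compound so far sitting at the limit. The step of a number no higher from compound 3 to compound 4 (the limit leaves the size open) expected for compound 4 is none that this assay could read. The estimate for compound 4 in this assay is 100000 nM, with a range from 60000 nM to 300000 nM, and most likely only the limit will be reported again.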

Compound 4, half-maximal cytotoxic concentration: > 100000 nM
Compound 4: only a limit was reported (the forecaster's own chance of this, stated with the estimate: 85%); the middle value lies on the limit itself.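

No step can be read from compound 3 to compound 4, as both results are limits and not numbers: the limit of > 100000 nM in this assay, at which 4 of the 4 values shown sit.

The compounds shown leave open what concentration of any of them is actually tolerated in this assay, and whether lengthening the hydroxyalkyl chain changes it.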